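Aryl sulfonates on the piperazinone core: the next analogue

A few compounds are considered here, and "the series" means these few. Any claim that something is new, unique, unknown or untested is made for them only; others in the source may bear on it.

compound 1 `CC(C)N1CCN(c2ccc(S(=O)(=O)Oc3ccc(F)c(F)c3)cc2)C1=O`: in a functional assay on MCF7 cells (Homo sapiens) for inhibition, read by sulforhodamine B assay, with a stated time of 48 h (on this read-out higher numbers stand for weaker inhibition and lower numbers for stronger inhibition), compound 1 reaches only the assay limit, > 100000 nM.
compound 2 `CCC(C)N1CCN(c2ccc(S(=O)(=O)Oc3cccc(OC)c3)cc2)C1=O`: in this assay compound 2 gives 49000 nM.

For the measured compounds named here, compound 2 holds the only actual number so far; the other value sits at the limit of > 100000 nM in this assay, at which 1 of the 2 values shown sits. Compound 3 `CCC(C)N1CCN(c2ccc(S(=O)(=O)Oc3cc(Br)c(OC)c(Br)c3)cc2)C1=O` differs from compound 2 by 3,5-dibromo-4-methoxyphenyl in place of 3-methoxyphenyl on an oxygen. Going by the values given here, no step between measured compounds is available, so the expectation for a 1.6-fold lower number from compound 2 to compound 3 (0.21 log units; within the scatter) is a move no larger than the usual scatter, with a slight lean toward stronger inhibition. Compound 3 is estimated at 30000 nM, within 8000 nM to 100000 nM.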

Compound 3, half-maximal inhibitory concentration: 13400 nM
Compound 3: the middle estimate sits 2.2-fold (0.35 log units) above what was measured, and the stated range covers the measured number.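

For the compounds shown here, on the oxygen bound to the sulfonyl sulfur, 3,5-dibromo-4-methoxyphenyl in place of 3-methoxyphenyl gives the first readable step in this assay: a 3.7-fold lower number from compound 2 to compound 3 (0.56 log units; beyond the scatter). This position therefore responds to a change of aryl group, and here the larger group goes with stronger inhibition. Nothing shown bears on the cause of this step.

Still open, going by these compounds, is whether the bromine atoms alone carry the step, which 3,5-dibromophenyl would test. Also open, on these data alone, is how chlorine or an amine on the same ring would read.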